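Working notes: methyl in place of chloro, lipophilicity series

The source may report more compounds than this note shows. Statements on the series, on what has been measured and on what is new or still open speak of the compounds shown alone.

Measured compounds:
- compound 1 `CCCc1nc2ccccc2c(=O)n1/N=C/c1ccc(Oc2ccc(Cl)cc2)cc1`: 5.78
- compound 2 `Cc1nc2ccccc2c(=O)n1/N=C/c1ccc(Oc2ccc(Cl)cc2)cc1`: 4.6
- compound 3 `O=c1c2ccccc2nc(-c2ccccc2)n1/N=C/c1ccc(Oc2ccc(Br)cc2)cc1`: 6.39

In a physicochemical assay for lipophilicity, in phosphate buffer, measured as octanol-water partition (on this read-out lower numbers stand for lower lipophilicity and higher numbers for higher lipophilicity), compound 2 gives the lowest of the three numbers. Among the compounds with values here, its nearest neighbour is compound 1, and the step of a number 1.18 log units lower from compound 1 to compound 2 (beyond the scatter) is the only one-place step among the measured compounds. Compound 3, with 6.39 in this assay, stands further away still and differs from compound 2 in more than one place.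

Compound 4 `Cc1ccc(Oc2ccc(/C=N/n3c(C)nc4ccccc4c3=O)cc2)cc1` is not yet measured in this assay. Its change from compound 2 is methyl in place of chloro on an aromatic carbon. Within the data shown here, no measured step bears on this change: the step from compound 1 to compound 2 concerns a saturated chain carbon bound to an aromatic carbon, not an aromatic carbon of a six-membered aromatic ring of carbon only, and compound 3 changes several things at once. The expectation for compound 4 therefore rests on the exchange alone, and a step of about a number 0.15 log units lower from compound 2 to compound 4 (within the scatter) is estimated, that is, no step beyond the scatter in either direction. For compound 4 the estimated value in this assay is 4.45, within a range from 4 to 4.9.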

Compound 4, partition coefficient: 4.32
Beside the measured number, compound 4's estimate is 0.13 log units above it, within the range that was stated.
By their numbers in this assay, from the lowest: compounds 4 and 2 (each within the scatter of the next); then compound 1; then compound 3.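

In this assay, methyl in place of chloro on an aromatic carbon, para to a large group, gives a number 0.28 log units lower from compound 2 to compound 4 (within the scatter) and so does not separate the two groups at this position. Within the data shown here, this is the first one-place reading at the 4-chlorophenoxy end of the series; the earlier step, a number 1.18 log units lower from compound 1 to compound 2 (beyond the scatter) and printed as beyond the scatter, lies on a saturated chain carbon and says nothing about this place. No supporting data bear on why chloro and methyl read alike here.

Still open, going by these compounds, is how a group of another kind, such as an amine or a carboxylic acid, would read at this same place. Also open, on these data alone, is whether methyl and chloro still read alike on the core of compound 1, which carries the longer chain.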